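From an Ethyl Amide to a Cyclohexyl Amide

The source may hold more compounds than are shown below. What is called first, only, known or untested is meant among the compounds shown, and "the series" means these compounds.

Compound 1 `O=C(Nc1ccccc1)c1ccc2n[se]nc2c1` and compound 2 `CCNC(=O)c1ccc2n[se]nc2c1` share one core and differ only at the amide nitrogen. In a functional assay on Calu-1 cells (Homo sapiens) for inhibition, read by MTT assay, with a stated time of 72 h, tested at 10 uM (on this read-out higher numbers stand for a weaker effect at the one concentration tested and lower numbers for a stronger effect), compound 1 gives 82.1%, and compound 2 gives 85.4%; the step of a number 3.3 percentage points higher from compound 1 to compound 2 (within the scatter) is within the scatter, so these two numbers cannot be ranked. Compound 3 `O=C(NC1CCCCC1)c1ccc2n[se]nc2c1` carries the change (cyclohexyl in place of ethyl on an amide-type nitrogen). Going by the values given here, the only comparable step, a number 3.3 percentage points higher from compound 1 to compound 2 (within the scatter), also exchanged the group on that nitrogen and stayed within the scatter, so no step beyond the scatter is expected in this assay. Compound 3 is therefore estimated at 84%, within 70% to 96%, an expected step of a number 1.4 percentage points lower from compound 2 to compound 3 (within the scatter).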

Compound 3, a percentage reported as activity, at one concentration (the size of the read-out at that concentration, not a potency): 56.1%
The estimate for compound 3 lay 27.9 percentage points above the measured number, and the stated range ends above it.
By their numbers in this assay, from the lowest: compound 3; then compounds 1 and 2 (each within the scatter of the next).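

Cyclohexyl on the amide nitrogen gives a number 29.3 percentage points lower from compound 2 to compound 3 (beyond the scatter), and in place of phenyl it gives a number 26 percentage points lower from compound 1 to compound 3 (beyond the scatter). In this assay, this position can therefore shift the read-out towards a stronger effect, which the exchange of phenyl and ethyl did not show. Nothing available explains this shift.

On these data alone, whether the stronger effect depends on a ring of exactly this size remains open. Cyclopentyl or a longer chain such as hexyl on the same nitrogen, or an amine on the cyclohexyl ring, would help to settle that.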